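Working notes: 1-cyanocyclopentyl in place of 5-methyl-1,2-oxazol-3-yl

The source may hold more compounds than are shown below. What is called first, only, known or untested is meant among the compounds shown, and "the series" means these compounds.

Measured so far in a functional assay on HUVEC cells (Homo sapiens) for inhibition, read by CellTiter-Glo, with a stated time of 72 h; on this read-out higher numbers stand for weaker inhibition and lower numbers for stronger inhibition:
- compound 1 `COc1cc2ncnc(Oc3ccc(NC(=O)Nc4ccc(Cl)c(C(F)(F)F)c4)c4ccccc34)c2cc1OC`: 2970 nM
- compound 2 `COc1cc2ncnc(Oc3ccc(NC(=O)Nc4cc(C)on4)c4ccccc34)c2cc1OC`: "not determined" (no result reported)

Compound 2 has no single number here: its entry reads "not determined" (no result reported), so it cannot serve as a starting point on the scale. The only figure in the series comes from compound 1, at 2970 nM.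

The next structure is compound 3 `COc1cc2ncnc(Oc3ccc(NC(=O)NC4(C#N)CCCC4)c4ccccc34)c2cc1OC`. The change reads 1-cyanocyclopentyl in place of 5-methyl-1,2-oxazol-3-yl on an amide-type nitrogen: a five-membered non-aromatic ring of carbon only replaces a five-membered aromatic ring with 2 hetero atoms.

Within the data shown here, no step from compound 2 can be sized. Measured against compound 1 at 2970 nM, a modest move towards weaker inhibition in this assay is expected, possibly not beyond the scatter. The expected value for compound 3 is 5000 nM, with an estimated range of 1500 nM to 15000 nM.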

Compound 3, half-maximal inhibitory concentration: 3620 nM
The estimate for compound 3 lay 1.4-fold (0.14 log units) above the measured number; low and high end bracket the measured number.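

In this assay the exchange of 4-chloro-3-(trifluoromethyl)phenyl for 1-cyanocyclopentyl on the amide-type nitrogen gives a 1.2-fold higher number from compound 1 to compound 3 (0.09 log units; within the scatter), so this position now carries two quite different groups, one aromatic and one a five-membered non-aromatic ring of carbon only, with no separation on this read-out. The step from compound 2 to compound 3 cannot be read, as compound 2 has no number, and the 5-methyl-1,2-oxazol-3-yl group therefore stays unplaced on the scale. No evidence bears on why the two groups read alike.

As far as these compounds go, whether the nitrile matters stays open, since plain cyclopentyl would separate it from the ring. Equally open, from the compounds shown here alone, is how this position would respond to a smaller 1-cyanocyclopropyl group, an open tert-butyl group or a chain ending in an amine.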